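The compounds below may be only part of what the source reports. "The series", "measured", "known", "first", "only" and "open" are said of these compounds alone.

In a functional assay on MCF7 cells (Homo sapiens) for inhibition, read by fluorescence, with a stated time of 72 h (a lower number here means a stronger inhibitor, a higher number a weaker inhibitor), compound 1 (`CC(C)n1cnc2c(NC(=N)N)nc(NC3CC3)nc21`) gives 5400 nM and compound 2 (`CC(C)n1cnc2c(NC(=N)N)nc(N3CCC[C@H]3CO)nc21`) gives 6200 nM, so compound 2 stands level with compound 1, the measured step being a 1.1-fold higher number from compound 1 to compound 2 (0.06 log units; within the scatter). Compound 3 (`CC(C)n1cnc2c(NC(=N)N)nc(N3CCC[C@@H]3CO)nc21`) differs from compound 2 in this way: the two compounds have the same atoms and bonds; at least one stereo element is drawn with a configuration in one of them and without one in the other: 1 of 2 stereo elements differ; a stereocentre at a saturated ring carbon is drawn S in compound 2 and R in compound 3. Within the data shown here, only that one measured step bears on the change, and it exchanges cyclopropylamino for 2-(hydroxymethyl)pyrrolidin-1-yl, so no measurement tests the configuration itself. No step beyond the scatter is therefore expected in this assay. The estimate for compound 3 is 6000 nM, with an expected range of 2500 nM to 14000 nM. The estimated step is a 1.0-fold lower number from compound 2 to compound 3 (0.01 log units; within the scatter).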

Compound 3, half-maximal inhibitory concentration: 20400 nM
Compound 3: the middle estimate sits 3.4-fold (0.53 log units) below what was measured, and the stated range ends below it.
By their numbers in this assay, from the lowest: compounds 1 and 2 (each within the scatter of the next); then compound 3.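

In this assay, the configuration at the saturated ring carbon proves to count, with a 3.3-fold higher number from compound 2 to compound 3 (0.52 log units; beyond the scatter), although the earlier exchange of groups had moved nothing beyond the scatter. The same exchange of cyclopropylamino for 2-(hydroxymethyl)pyrrolidin-1-yl, taken with the R configuration, gives a 3.8-fold higher number from compound 1 to compound 3 (0.58 log units; beyond the scatter), so its outcome rests on the configuration drawn. The record at this place holds only this: the fact that one of compounds 2 and 3 is drawn with a defined configuration and the other without, at the place where they differ

The compounds shown leave open whether the configuration still counts when the hydroxymethyl group gives way to a carboxylic acid, an amine or a longer chain.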